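This account rests on a few compounds, and the source may have more. Where it says the series, first, only, none or still open, it means among the compounds named here.

Working notes on the series in an in vitro assay on HEK385-7 cells for displacement of a labelled ligand from prostaglandin D2 receptor 2 (Homo sapiens); on this read-out lower numbers stand for stronger inhibition and higher numbers for weaker inhibition.

compound 1, `O=C(O)Cc1sc(C(c2ccc(F)cc2)c2ccc(F)cc2)nc1-c1ccccc1`: 16 nM
compound 2, `N#Cc1cc(-c2nc(C(c3ccc(F)cc3)c3ccc(F)cc3)sc2CC(=O)O)ccc1F`: 57 nM
compound 3, `O=C(O)Cc1sc(C(c2ccc(F)cc2)c2ccc(F)cc2)nc1-c1ccco1`: 18 nM

Compound 3 holds the second highest of the three numbers. Its nearest neighbour is compound 1, with a 1.1-fold higher number from compound 1 to compound 3 (0.05 log units; within the scatter); its furthest is compound 2, with a 3.2-fold lower number from compound 2 to compound 3 (0.50 log units; beyond the scatter). For the measured compounds named here, the only step that moved beyond the scatter in this assay is a 3.6-fold higher number from compound 1 to compound 2 (0.55 log units; beyond the scatter), a modest weakening on exchanging phenyl for 3-cyano-4-fluorophenyl on an aromatic carbon.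

Compound 4, `O=C(O)Cc1sc(C(c2ccc(F)cc2)c2ccc(F)cc2)nc1-c1ccncc1`, has not yet been measured. It differs from compound 3 in one place: pyridin-4-yl in place of furan-2-yl on an aromatic carbon.

Going by the values given here, two measured steps bear on this change. The step of a 1.1-fold higher number from compound 1 to compound 3 (0.05 log units; within the scatter) shows that swapping phenyl for a five-membered aromatic ring with one hetero atom on this aromatic carbon leaves the number where it was. The step of a 3.6-fold higher number from compound 1 to compound 2 (0.55 log units; beyond the scatter) shows that a larger aromatic group at the same carbon raised the number modestly. Among the compounds with values here, no measured step involves a six-membered ring with one hetero atom at this position, so the expectation leans on these two alone: little change, possibly a slight rise, most likely within or just beyond the scatter.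

Compound 4 is therefore expected to give 25 nM, with a range from 10 nM to 70 nM. The expected step is a 1.4-fold higher number from compound 3 to compound 4 (0.14 log units; within the scatter).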

Compound 4, half-maximal inhibitory concentration: 5.3 nM
Compound 4: middle estimate off by 4.7-fold (0.67 log units), on the high side; measured number outside the range, below it.
By their numbers in this assay, from the lowest: compound 4; then compounds 1 and 3 (each within the scatter of the next); then compound 2.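

Among the groups shown at this aromatic carbon, next to the ring nitrogen and next to the ring atom that bears a carboxymethyl group, only pyridin-4-yl lowers the number beyond the scatter in this assay: a 3.0-fold lower number from compound 1 to compound 4 (0.48 log units; beyond the scatter) and a 3.4-fold lower number from compound 3 to compound 4 (0.53 log units; beyond the scatter), and the widest gap in the series is an 11-fold lower number from compound 2 to compound 4 (1.03 log units; beyond the scatter). The earlier compounds shown here showed only a flat step or a rise at this carbon, so the change reveals that the number here can also fall, and that a six-membered aromatic ring can sit at either end of the series, as compound 1, compound 2 and compound 4 all carry one. The data shown give no measurement that would explain the fall.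

The compounds shown leave open whether the fall depends on where the ring nitrogen stands, which pyridin-3-yl or pyridin-2-yl at the same carbon would test, and whether a second ring nitrogen, as in pyrimidin-5-yl, would move the number further. Also open, as far as these compounds go, is whether substituents on the pyridin-4-yl ring, such as an amine or a fluorine, would keep the number of compound 4 or raise it, as the 3-cyano-4-fluorophenyl group of compound 2 does relative to phenyl.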